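A sec-Butyl Ester in Place of the Diethylamide

The source may hold more compounds than are shown below. What is called first, only, known or untested is meant among the compounds shown, and "the series" means these compounds.

Of the compounds shown here, three sharing one core have been tested in an assay on membranes from HeLa cells for displacement of a labelled ligand from adenosine receptor A3 (Homo sapiens), read by scintillation counting, with a stated time of 180 min, tested at 1 uM; on this read-out lower numbers stand for less inhibition and higher numbers for more inhibition at the one concentration tested (going by the name of the read-out). Compound 1 `CC1=C(C(=O)OCc2ccccc2)C(c2ccco2)NC(=O)N1` gives 3%, compound 2 `CCCC(=O)C1=C(C)NC(=O)NC1c1ccco1` gives 1%, and compound 3 `CCN(CC)C(=O)C1=C(C)NC(=O)NC1c1ccco1` gives 19%. Among the compounds with values here, the single one-place step among them runs a number 18 percentage points higher from compound 2 to compound 3 (beyond the scatter), and compound 3 stands highest of the three, above compound 1 and compound 2, both beyond the scatter.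

Compound 4 `CCC(C)OC(=O)C1=C(C)NC(=O)NC1c1ccco1` differs from compound 3 at one place: sec-butoxy in place of diethylamino on a carbonyl carbon. The change sits on a carbonyl carbon whose other neighbour is a double-bonded ring carbon. Within the data shown here, no measured step covers this change directly. What bears on it is that compound 3, the only one carrying a diethylamino at that carbonyl carbon, stands apart, while compound 1, carrying an ester there, gives 3%. Compound 4 is therefore expected to move back toward the lower numbers, a step of roughly a number 14 percentage points lower from compound 3 to compound 4 (beyond the scatter). The estimate for compound 4 in this assay is 5%, with a range from 0% to 15%.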

Compound 4, a percentage reported as inhibition, at one concentration (the size of the read-out at that concentration, not a potency): 3%
Beside the measured number, compound 4's estimate is 2 percentage points above it; low and high end bracket the measured number.
By their numbers in this assay, from the lowest: compounds 2, 1 and 4 (each within the scatter of the next); then compound 3.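

In this assay, the exchange of diethylamino for sec-butoxy on this carbonyl carbon gives a number 16 percentage points lower from compound 3 to compound 4 (beyond the scatter), so the higher number of compound 3 does not carry over to this ester, although both groups hold 5 heavy atoms. Within the data shown here, the other two comparisons show little sensitivity among the non-amide groups at this place: sec-butyl in place of benzyl on the ester oxygen gives no change at the digits printed from compound 1 to compound 4 (within the scatter), and sec-butoxy in place of propyl gives a number 2 percentage points higher from compound 2 to compound 4 (within the scatter), leaving diethylamino as the only group here that stands apart. No available evidence accounts for this difference.

On these data alone, whether a smaller dimethylamino group, a cyclic pyrrolidine amide or a secondary ethylamide would hold or raise the number remains open. So does the outcome with a free carboxylic acid on this carbonyl carbon.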